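This account rests on a few compounds, and the source may have more. Where it says the series, first, only, none or still open, it means among the compounds named here.

Compound 1 `COc1cccc(CNc2ncnc3c2ncn3C2CCCCO2)c1` and compound 2 `COc1ccc(CNc2ncnc3c2ncn3C2CCCCO2)cc1` share one core and differ only as 3-methoxyphenyl in place of 4-methoxyphenyl on a saturated chain carbon bound to a nitrogen on an aromatic ring. In an ADME assay on BJ cells (Homo sapiens) for cytotoxicity, read by MTT assay, with a stated time of 72 h (on this read-out higher numbers stand for weaker inhibition and lower numbers for stronger inhibition), compound 1 gives only a limit of the assay, > 100000 nM. Compound 2 likewise gives only a limit, > 100000 nM. The step that the two limits leave unreadable from compound 1 to compound 2 therefore rests on (the limit of > 100000 nM in this assay, at which 2 of the 3 values shown sit). Compound 3 `COc1ccc(CNc2ncnc3c2ncn3C2CCCCO2)c(OC)c1` carries the change (methoxy in place of hydrogen on an aromatic carbon); in this assay compound 3 gives only a limit, > 25000 nM. The step that the two limits leave unreadable from compound 2 to compound 3 is bounded by the limit of > 100000 nM in this assay, at which 2 of the 3 values shown sit, and (the limit of > 25000 nM in this assay, at which 1 of the 3 values shown sits). Compound 4 `COc1cc(CNc2ncnc3c2ncn3C2CCCCO2)cc(OC)c1` carries the same kind of change made on compound 1, (methoxy in place of hydrogen on an aromatic carbon), the methoxy entering meta to a large group rather than ortho to a large group. Beside the step from compound 2 to compound 3, the step that the limit leaves unreadable from compound 1 to compound 4 in this assay is expected to be small, because a step that the two limits leave unreadable from compound 2 to compound 3 gave no readable movement. Compound 4 is accordingly expected to give about 150000 nM.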

Compound 4, half-maximal inhibitory concentration: > 100000 nM
Compound 4 ended at the assay's limit; the forecaster's own chance of this, stated with the estimate: 85%; the middle value is on the limit's open side.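

Going by these compounds alone, compound 1 and compound 4 both give only a limit in this assay, and no step between them can be read. The compounds shown leave open whether adding a methoxy group changes the value in this assay at all.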